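The source may hold more compounds than are shown below. What is called first, only, known or untested is meant among the compounds shown, and "the series" means these compounds.

In a functional assay on HepG2 cells (Homo sapiens) for antiproliferative activity, read by MTT assay, with a stated time of 48 h (on this read-out higher numbers stand for weaker inhibition of growth and lower numbers for stronger inhibition of growth), compound 1 (`COC(=O)N1N=C(c2ccccc2)CC1c1cc(OC)c(OC)c(OC)c1`) gives 3950 nM and compound 2 (`CCOC(=O)N1N=C(c2ccccc2)CC1c1cc(OC)c(OC)c(OC)c1`) gives 5950 nM as its result. Going by the values given here, these two values lie within the usual scatter of each other, so compound 2 stands level with compound 1 on the numbers so far. Compound 3 (`CCCOC(=O)N1N=C(c2ccccc2)CC1c1cc(OC)c(OC)c(OC)c1`) differs from compound 2 by methyl in place of hydrogen on a saturated chain carbon, two bonds along the chain from an oxygen next to a carbonyl group in the change from ethoxy to propoxy: methyl in place of hydrogen on a saturated chain carbon, two bonds along the chain from an oxygen next to a carbonyl group. Among the compounds with values here, one measured step bears on this, a similar lengthening of the same chain, and it amounts to a 1.5-fold higher number from compound 1 to compound 2 (0.18 log units; within the scatter) and no more. Within the data shown here, with only that guide, no change beyond the scatter is expected in this assay for this further methyl. The expected step is a 1.2-fold higher number from compound 2 to compound 3 (0.07 log units; within the scatter) at most a slight drift upward. Compound 3 is estimated at 7000 nM with an expected range from 3500 nM to 14000 nM in repeated measurements.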

Compound 3, concentration for 50% growth inhibition: > 10000 nM
Compound 3: a limit, no number; the forecaster's own chance of this, stated with the estimate: 3%; middle value at least 1.4-fold (0.15 log units) away from the limit.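

In this assay compound 3 gives > 10000 nM, which is a limit of the assay and not a number. Going by these compounds, the single added methyl is an at least 1.6-fold higher number from compound 2 to compound 3 (0.22 log units; that floor lies within the scatter), so that floor alone does not show a real change at this position, and the true size of the step stays unknown. Going by these compounds alone, the comparison across the whole chain is an at least 2.5-fold higher number from compound 1 to compound 3 (0.40 log units; beyond the scatter), the first step here to pass the scatter and a sign of weaker inhibition of growth with the propoxy chain.

On these data alone, how far compound 3 lies past its limit remains open. Also open, as far as these compounds go, is how a longer chain, a branched chain or an amine in place of the propoxy chain would read.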